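From bromoethenyl to methyl at the antiproliferative limit

The source may report more compounds than this note shows. Statements on the series, on what has been measured and on what is new or still open speak of the compounds shown alone.

In a functional assay on CCRF-HSB-2 cells (Homo sapiens) for antiproliferative activity (a lower number here means a stronger inhibitor, a higher number a weaker inhibitor), compound 1 (`Cc1cn([C@@H]2S[C@H](CO)[C@@H](O)[C@@H]2O)c(=O)[nH]c1=O`) gives > 100 ug/mL as a limit of the assay and not as a number. Compound 2 (`O=c1[nH]c(=O)n([C@H]2S[C@H](CO)[C@@H](O)[C@@H]2O)cc1/C=C/Br`) gives > 100 ug/mL and this too is only a limit. Compound 2 therefore stands at the limit of > 100 ug/mL in this assay, at which 2 of the 2 values shown sit, and has no measured number from which to count. Among the measured compounds shown here, compound 3 (`Cc1cn([C@H]2S[C@H](CO)[C@@H](O)[C@@H]2O)c(=O)[nH]c1=O`) differs from compound 2 by one change, methyl in place of 2-bromoethenyl on an aromatic carbon and no measured step shows what such a change does here. No step beyond the usual scatter is expected in this assay in either direction, though a shift towards stronger inhibition remains possible. The estimated step is a number no higher from compound 2 to compound 3 (the limit leaves the size open) as the expected outcome. Compound 3 is expected near 100 ug/mL with an estimated range from 30 ug/mL to 200 ug/mL and may well return only a limit again.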

Compound 3, half-maximal inhibitory concentration: 42 ug/mL
Estimate against measurement, compound 3: 2.4-fold (0.38 log units) above; the range from low to high includes it.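

At this position, the exchange of 2-bromoethenyl for methyl is not silent in this assay: it gives an at least 2.3-fold lower number from compound 2 to compound 3 (0.37 log units; beyond the scatter). Methyl alone does not decide the outcome, however: with methyl kept, a change of configuration at a saturated ring carbon gives an at least 2.3-fold lower number from compound 1 to compound 3 (0.37 log units; beyond the scatter). That second step can be placed on configuration alone because of one fact: the fact that compounds 1 and 3 differ only in the configuration as drawn.

As far as these compounds go, the true size of both steps stays open, as each starts from a value that is only a limit: the limit of > 100 ug/mL in this assay, at which 2 of the 3 values shown sit. Also open, from the compounds shown here alone, is how a longer chain or an amine at this position would compare with the methyl group of compound 3 in this assay.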